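A few compounds are considered here, and "the series" means these few. Any claim that something is new, unique, unknown or untested is made for them only; others in the source may bear on it.

Measured so far: compound 1 `CC(=O)N(C)c1ccc2[nH]c(-c3n[nH]c4ccccc34)cc2n1`, compound 2 `CCC(=O)N(C)c1ccc2[nH]c(-c3n[nH]c4ccccc34)cc2n1`, compound 3 `CN(C(=O)c1ccco1)c1ccc2[nH]c(-c3n[nH]c4ccccc34)cc2n1`.

In a functional assay on A549 cells (Homo sapiens) for antiproliferative activity, read by MTT assay, with a stated time of 72 h (on this read-out lower numbers stand for stronger inhibition and higher numbers for weaker inhibition), compound 1 reaches only the assay limit, > 50000 nM. Compound 2 gives 15700 nM. Compound 3 gives 15500 nM, the lowest of the two numbers, with compound 2 within the scatter of it (a 1.0-fold lower number from compound 2 to compound 3 (0.01 log units; within the scatter)). The third value, that of compound 1, is a limit (the limit of > 50000 nM in this assay, at which 1 of the 3 values shown sits).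

Compound 4 is `Cc1ccc(S(=O)(=O)N(C)c2ccc3[nH]c(-c4n[nH]c5ccccc45)cc3n2)cc1`; it differs from compound 3 by (4-methylphenyl)sulfonyl in place of (furan-2-yl)carbonyl on a nitrogen on an aromatic ring. Among the compounds with values here, no measured step exchanges a carbonyl for a sulfonyl. Within the data shown here, the steps that bear on it are an at least 3.1-fold lower number from compound 1 to compound 2 (0.50 log units; beyond the scatter), an at least 3.2-fold lower number from compound 1 to compound 3 (0.50 log units; beyond the scatter) and a 1.0-fold lower number from compound 2 to compound 3 (0.01 log units; within the scatter): once the group on this nitrogen is larger than acetyl, the numbers have stayed at one level. Hence no step beyond the scatter is expected, a 1.0-fold lower number from compound 3 to compound 4 (0.01 log units; within the scatter). Compound 4 is estimated at 15000 nM in this assay, within 5000 nM to 50000 nM.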

Compound 4, half-maximal inhibitory concentration: 27100 nM
Compound 4: the middle estimate sits 1.8-fold (0.26 log units) below what was measured; low and high end bracket the measured number.
By their numbers in this assay, from the lowest: compounds 3, 2 and 4 (each within the scatter of the next). At a limit, above all of these: compound 1.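

In this assay, (4-methylphenyl)sulfonyl on this nitrogen gives no change beyond the scatter from either acyl group: a 1.7-fold higher number from compound 3 to compound 4 (0.24 log units; within the scatter) and a 1.7-fold higher number from compound 2 to compound 4 (0.24 log units; within the scatter). A sulfonyl thus holds the level of the carbonyl compounds here, with a different aromatic ring and more heavy atoms. Compound 1 stands at a limit, so an at least 1.8-fold lower number from compound 1 to compound 4 (0.26 log units; that floor lies within the scatter) does not separate the two: the limit of > 50000 nM in this assay, at which 1 of the 4 values shown sits.

Open, as far as these compounds go, is how a smaller sulfonyl, such as methanesulfonyl, would read on this nitrogen. Also open, from the compounds shown here alone, is whether an acyl chain carrying an amine or a carboxylic acid would leave this level.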